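The source may hold more compounds than are shown below. What is called first, only, known or untested is meant among the compounds shown, and "the series" means these compounds.

Working notes on the series. Compound 1 `Cn1ncnc1-c1ccccc1NCC1=NCCN1` is the reference point; in an in vitro functional assay on cells (Fibroblast) for agonist activity at Alpha-1B adrenergic receptor (Homo sapiens) (on this read-out higher numbers stand for an effect only at larger amounts of compound and lower numbers for an effect already at smaller amounts), compound 1 gives 39.8 nM. Compound 2 `CCn1ncnc1-c1ccccc1NCC1=NCCN1` carries methyl in place of hydrogen on a saturated chain carbon bound to an aromatic nitrogen. In this assay compound 2 gives 63.1 nM, and the step of a 1.6-fold higher number from compound 1 to compound 2 (0.20 log units; within the scatter). Compound 3 `CCn1nccc1-c1ccccc1NCC1=NCCN1` sits on another core; the difference between the two cores is not broken down here. In this assay compound 3 reports only a limit, < 100000 nM, which is the limit of < 100000 nM in this assay, at which 1 of the 3 values shown sits. Compound 4 `CCCn1nccc1-c1ccccc1NCC1=NCCN1` is not yet measured and carries methyl in place of hydrogen on a saturated chain carbon, two bonds along the chain from an aromatic nitrogen. Among the measured compounds shown here, this is the same kind of change as the one from compound 1 to compound 2, though the place is not identical: there the methyl enters on a saturated chain carbon bound to an aromatic nitrogen, here on a saturated chain carbon, two bonds along the chain from an aromatic nitrogen. Since the measured step of a 1.6-fold higher number from compound 1 to compound 2 (0.20 log units; within the scatter) lies within the scatter, a comparably small step is expected for compound 4, namely a step that the limit leaves unreadable from compound 3 to compound 4. The anchor for compound 3 is a limit only, so the expectation stays wide. Compound 4 is estimated at 20000 nM, expected to fall between 500 nM and 100000 nM.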

Compound 4, half-maximal effective concentration: < 100000 nM
Compound 4 ended at the assay's limit; the forecaster's own chance of this, stated with the estimate: 50%; the middle value does not contradict the limit.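

In this assay compound 3 and compound 4 both report only a limit, so no step can be read between them: the limit of < 100000 nM in this assay, at which 2 of the 4 values shown sit. The compounds shown leave open whether methyl in place of hydrogen on a saturated chain carbon, two bonds along the chain from an aromatic nitrogen, changes the read-out on this core at all.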